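Swapping a Methylphenyl for an Aminophenyl Group

The source may report more compounds than this note shows. Statements on the series, on what has been measured and on what is new or still open speak of the compounds shown alone.

Three ureas share one core and differ only in the aryl group attached to a saturated ring carbon. Compound 1 `Cc1ccccc1C1(CNC(=O)Nc2c(C(C)C)cccc2C(C)C)CCCC1` gives 17 nM in an assay on microsomes for inhibition of acyl-CoA:cholesterol acyltransferase (Oryctolagus cuniculus) (a higher number here means a weaker inhibitor, a lower number a stronger inhibitor), the lowest of the three numbers shown. Compound 2 `Cc1ccc(C2(CNC(=O)Nc3c(C(C)C)cccc3C(C)C)CCCC2)cc1` gives 25 nM in this assay, and the step is a 1.5-fold higher number from compound 1 to compound 2 (0.17 log units; within the scatter). Compound 3 `CC(C)c1ccc(C2(CNC(=O)Nc3c(C(C)C)cccc3C(C)C)CCCC2)cc1` gives 48 nM in this assay; here the step is a 2.8-fold higher number from compound 1 to compound 3 (0.45 log units; beyond the scatter), while from compound 2 the step is a 1.9-fold higher number from compound 2 to compound 3 (0.28 log units; within the scatter).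

Compound 4 `CC(C)c1cccc(C(C)C)c1NC(=O)NCC1(c2cccc(N)c2)CCCC1` has not yet been measured. It differs from compound 1 by 3-aminophenyl in place of 2-methylphenyl on a saturated ring carbon. For the measured compounds named here, none of the measured steps brings in an amino group, so only indirect evidence is at hand: changing the aryl group has so far moved the number by amounts that were within the scatter or modest. The step from compound 1 to compound 4 is therefore expected to be a 2.4-fold higher number from compound 1 to compound 4 (0.37 log units; beyond the scatter), a somewhat weaker inhibitor at most. Compound 4 is estimated at 40 nM, with a range from 15 nM to 120 nM.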

Compound 4, half-maximal inhibitory concentration: 21 nM
For compound 4 the middle estimate is 1.9-fold (0.28 log units) above the measured one; measured number inside the range.
By their numbers in this assay, from the lowest: compounds 1, 4, 2 and 3 (each within the scatter of the next, the first and the last beyond it).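

Placing 3-aminophenyl on the saturated ring carbon brings in a hydrogen-bond donor and acceptor that 2-methylphenyl and 4-methylphenyl lack, yet the number stays within the scatter of both (a 1.2-fold higher number from compound 1 to compound 4 (0.09 log units; within the scatter); a 1.2-fold lower number from compound 2 to compound 4 (0.08 log units; within the scatter)). Only the comparison with the 4-isopropylphenyl compound goes beyond the scatter, and modestly so (a 2.3-fold lower number from compound 3 to compound 4 (0.36 log units; beyond the scatter)), which shows that this position can carry an aryl group with an amino group as well as one with a methyl group. Nothing at hand accounts for this result.

The amino group in compound 4 also sits at a different ring position from the methyl groups in compounds 1 and 2, so a 3-methylphenyl group would be needed to separate the two changes. A 3-dimethylaminophenyl or 3-acetamidophenyl group would show whether the free amine's hydrogens matter here.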